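This account rests on a few compounds, and the source may have more. Where it says the series, first, only, none or still open, it means among the compounds named here.

Compound 1 `Nc1nc2ccc(-c3cn([C@@H]4CN[C@H](C(=O)Nc5ccc(Cl)cc5Cl)C4)nn3)nc2s1`: 24500 nM
Compound 2 `CC(=O)Nc1nc2ccc(-c3cn([C@@H]4CN[C@H](C(=O)Nc5ccc(Cl)cc5Cl)C4)nn3)nc2s1`: 9670 nM
Compound 3 `O=C(Nc1nc2ccc(-c3cn([C@@H]4CN[C@H](C(=O)Nc5ccc(Cl)cc5Cl)C4)nn3)nc2s1)C1CC1`: 740 nM

In a functional assay on K562 cells (Homo sapiens) for inhibition, read by MTT assay, with a stated time of 48 h (a lower number here means a stronger inhibitor, a higher number a weaker inhibitor), compound 2 stands second highest of the three, at 9670 nM. Compound 4 `CC(=O)Nc1nc2ccc(-c3cn([C@@H]4CN[C@H](C(=O)Nc5ccc(F)c(F)c5)C4)nn3)nc2s1` carries 3,4-difluorophenyl in place of 2,4-dichlorophenyl on an amide-type nitrogen. Among the measured compounds shown here, no measured step touches this group. The steps of a 2.5-fold lower number from compound 1 to compound 2 (0.40 log units; beyond the scatter), a 33-fold lower number from compound 1 to compound 3 (1.52 log units; beyond the scatter) and a 13-fold lower number from compound 2 to compound 3 (1.12 log units; beyond the scatter), modest to large, all change the other end of the molecule, so they bear on it only indirectly and give no direction. No shift beyond the scatter is therefore expected, and the expected step is a 1.1-fold higher number from compound 2 to compound 4 (0.06 log units; within the scatter). For compound 4 the estimated value is 11000 nM, with an expected range of 3500 nM to 35000 nM.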

Compound 4, half-maximal inhibitory concentration: 63000 nM
The estimate for compound 4 lay 5.7-fold (0.76 log units) below the measured number; measured number outside the range, above it.
By their numbers in this assay, from the lowest: compound 3; then compound 2; then compound 1; then compound 4.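

In this assay, 3,4-difluorophenyl in place of 2,4-dichlorophenyl gives a 6.5-fold higher number from compound 2 to compound 4 (0.81 log units; beyond the scatter), so the aryl group on the amide-type nitrogen also moves the number, which the steps at the other end of the molecule could not show. This single step changes both the halogen and its ring placement, so it cannot assign the shift to either. No measurement offered here accounts for the step. A 3,4-dichlorophenyl or 2,4-difluorophenyl group would separate those two changes. Going by these compounds, whether the step holds with the cyclopropylcarbonyl group of compound 3 also remains open.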